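The source may report more compounds than this note shows. Statements on the series, on what has been measured and on what is new or still open speak of the compounds shown alone.

Measured so far:
- compound 1, `C=CCONC(=O)Cn1cc(C(=O)NCC(=O)N[C@@H](CC(C)C)C(=O)O)c2ccccc21`: in a functional assay on MRC5 cells (Homo sapiens) for inhibition, read by microscopy and resazurin assay, with a stated time of 72 h (a higher number here means a weaker inhibitor, a lower number a stronger inhibitor), compound 1 reaches only a limit, > 128000 nM.
- compound 2, `C=CCONC(=O)Cn1cc(C(=O)N[C@@H](C)C(=O)N[C@@H](CC(C)C)C(=O)O)c2ccccc21`: in this assay compound 2 reaches only a limit, > 128000 nM.
- compound 3, `CC(C)[C@H](NC(=O)CNC(=O)c1ccn(CC(=O)NOCc2ccccc2)c1)C(=O)O`: in this assay compound 3 reaches only a limit, > 128000 nM.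

Compound 1 and compound 2 differ in one place, (methyl in place of hydrogen on a saturated chain carbon bound to an amide-type nitrogen and a carbonyl carbon). The step that the two limits leave unreadable from compound 1 to compound 2 cannot be sized, because both ends sit at the limit of > 128000 nM in this assay, at which 3 of the 3 values shown sit. Compound 3 shares this general build but its core differs from the core of compound 1 in more than one place; the difference between the two cores is not broken down here.

Compound 4, `CC(C)[C@H](NC(=O)[C@H](C)NC(=O)c1ccn(CC(=O)NOCc2ccccc2)c1)C(=O)O`, has not yet been measured. It carries the same change applied to compound 3, namely (methyl in place of hydrogen on a saturated chain carbon bound to an amide-type nitrogen and a carbonyl carbon), at the same place as in the move from compound 1 to compound 2.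

Within the data shown here, the only measured instance of this change gave no readable size, and every value in this assay so far sits at the limit of > 128000 nM in this assay, at which 3 of the 3 values shown sit. The step that the limit leaves unreadable from compound 3 to compound 4 is therefore expected to be unreadable in the same way, with no measured reason to expect the methyl to bring the value inside the measurable range. Compound 4 is expected to give about 200000 nM in this assay, within a range of 100000 nM to 600000 nM, most likely reported again as a limit only.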

Compound 4, half-maximal inhibitory concentration: > 128000 nM
Compound 4: no number, only a limit; the forecaster's own chance of this, stated with the estimate: 85%; the middle value lies beyond the limit too.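

No size can be read for the step from compound 3 to compound 4, as both compounds stop at a limit in this assay and the methyl in place of hydrogen therefore yields no number: the limit of > 128000 nM in this assay, at which 4 of the 4 values shown sit.

The compounds shown leave open whether this methyl has any effect on the half-maximal inhibitory concentration in this assay, and how any of these compounds would rank against another.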